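The source may report more compounds than this note shows. Statements on the series, on what has been measured and on what is new or still open speak of the compounds shown alone.

Working notes on the series.

Within the data shown here, compound 1 `Cc1cc(O)cc(-c2nn(CC#N)cc2-c2ccnc(-c3ccc(Oc4ccccc4)cc3)c2)c1` and compound 2 `COc1cc(C)cc(-c2nn(CC#N)cc2-c2ccnc(-c3ccc(N(C)C)cc3)c2)c1` share the same core and differ at two places at once, so no single-change step can be drawn between them. In a functional assay on MOLT-4 cells (Homo sapiens) for cytotoxicity, read by sulforhodamine B assay, with a stated time of 48 h, tested at 0.01 uM (a higher number here means a weaker effect of the compound at the concentration tested, a lower number a stronger effect), compound 1 gives 93%, and in the same this assay compound 2 gives 93%. Compound 2 therefore stands level with compound 1 at the digits shown, and the two values lie within the scatter of each other; neither compound can be called the stronger one on these numbers.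

Compound 3 `Cc1cc(O)cc(-c2nn(CC#N)cc2-c2ccnc(-c3ccc(N(C)C)cc3)c2)c1` has not been measured. Relative to compound 2 the change is hydrogen in place of methyl on an oxygen on an aromatic ring. The result is a compound that carries the hydroxy group of compound 1 together with the other end of compound 2.

Both measured compounds sit at the same weak level, so no step beyond the scatter is expected from compound 2 to compound 3 in this assay; the step of no change at the digits printed from compound 2 to compound 3 (within the scatter) is estimated as essentially flat. For compound 3 the expected value in this assay is 93%, with a likely range from 82% to 100%.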

Compound 3, a percentage reported as activity, at one concentration (the size of the read-out at that concentration, not a potency): 96%
Compound 3: the middle estimate sits 3 percentage points below what was measured; the measured number falls inside the stated range.
By their numbers in this assay, from the lowest: compounds 1, 2 and 3 (each within the scatter of the next).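

In this assay, methoxy to hydroxy on the aromatic ring gives a number 3 percentage points higher from compound 2 to compound 3 (within the scatter) and thus shows that, in the presence of the dimethylamino end, the methyl on this oxygen can go without a step beyond the scatter. Compound 3 also supplies a second single-change comparison at the other end of the molecule: dimethylamino in place of phenoxy on an aromatic carbon gives a number 3 percentage points higher from compound 1 to compound 3 (within the scatter) and, with the hydroxy group held constant, likewise shows no step beyond the scatter. No supporting data bear on this result.

All three compounds sit at the same weak level at the one concentration tested, so these readings cannot show whether either change would matter at a concentration where the effect on the cells is larger. Also open, from the compounds shown here alone, is how the read-out would respond to an ethoxy group or a longer chain on this oxygen, or to an amine or a carboxylic acid in place of the hydroxy group.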